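Removing a Fluoro Group from a Dichloro Anilide

A few compounds are considered here, and "the series" means these few. Any claim that something is new, unique, unknown or untested is made for them only; others in the source may bear on it.

Compound 1 `O=C(Nc1ccc(F)cc1F)c1cc(Cl)ccc1O` and compound 2 `O=C(Nc1ccc(F)cc1)c1cc(Cl)ccc1O` share one core, and compound 2 differs from compound 1 by hydrogen in place of fluoro on an aromatic carbon. In a physicochemical assay for solubility (a higher number here means a more soluble compound, a lower number a less soluble compound), compound 1 gives 1 ug/mL. In this assay compound 2 gives 1.6 ug/mL. The step is a 1.6-fold higher number from compound 1 to compound 2 (0.20 log units; within the scatter), so the two values cannot be told apart.

Compound 3 `O=C(Nc1c(Cl)cc(F)cc1Cl)c1cc(Cl)ccc1O` has a different core, and how it differs from the core of compound 1 is not broken down here. In this assay compound 3 reaches only a limit of the measurement, > 49 ug/mL. Compound 3 thus sits at the limit of > 49 ug/mL in this assay, at which 1 of the 3 values shown sits.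

Compound 4 `O=C(Nc1c(Cl)cccc1Cl)c1cc(Cl)ccc1O` differs from compound 3 by hydrogen in place of fluoro on an aromatic carbon. This is the same kind of change as between compound 1 and compound 2, yet the place is not identical: in compound 3 the carbon is meta to two chloro groups and para to a large group, whereas in compound 1 it is ortho to a large group and meta to a fluoro group. The step from compound 3 to compound 4 is expected to be small, a step that the limit leaves unreadable from compound 3 to compound 4, resting on the earlier 1.6-fold higher number from compound 1 to compound 2 (0.20 log units; within the scatter). Compound 4 is therefore estimated to give about 60 ug/mL in this assay, between 20 ug/mL and 150 ug/mL, and may again be reported only as a limit.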

Compound 4, solubility: 21 ug/mL
Estimate against measurement, compound 4: 2.9-fold (0.46 log units) above; measured number inside the range.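

In this assay, hydrogen in place of fluoro on the core of compound 3 gives an at least 2.3-fold lower number from compound 3 to compound 4 (0.36 log units; beyond the scatter), while the same kind of change on the core of compound 1 gives a 1.6-fold higher number from compound 1 to compound 2 (0.20 log units; within the scatter), so the small step seen on one core did not carry over to the other. The swap also sits at a different place in each pair, and these two pairs alone cannot tell whether the core, the place or something else lies behind the difference. Compound 3 stands at a limit and not at a number, so the true size of its step stays unknown and only its lower bound can be read: the limit of > 49 ug/mL in this assay, at which 1 of the 4 values shown sits.

As far as these compounds go, how an amine or a carboxylic acid on that same aromatic carbon would read in this assay remains open. Also open, from the compounds shown here alone, is whether replacing fluoro with hydrogen would give a small step or a clear one on any third core.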